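Amide to Urea: Expecting the Next Growth Inhibition Value

The compounds below may be only part of what the source reports. "The series", "measured", "known", "first", "only" and "open" are said of these compounds alone.

Compound 1 `COc1cc(-c2nn(-c3cccc(NC(=O)Nc4cc(C(F)(F)F)cc(C(F)(F)F)c4)c3)cc2-c2ccncc2)ccc1Cl` gives 1570 nM in a functional assay on COLO 205 cells (Homo sapiens) for inhibition, read by sulforhodamine B assay, with a stated time of 48 h; a higher number here means a weaker inhibitor of growth, a lower number a stronger inhibitor of growth.
Compound 2 `COc1cc(-c2nn(-c3cccc(NC(=O)c4cccc(C(F)(F)F)c4)c3)cc2-c2ccncc2)ccc1Cl` gives 5170 nM in this assay.

Of these two numbers, compound 2 has the higher one, and its gap to compound 1 lies beyond the usual scatter. Compound 3 `COc1cc(-c2nn(-c3cccc(NC(=O)Nc4cccc(C(F)(F)F)c4)c3)cc2-c2ccncc2)ccc1Cl` is not yet measured. It differs from compound 2 by (3-(trifluoromethyl)phenyl)amino in place of 3-(trifluoromethyl)phenyl on a carbonyl carbon, which makes it a urea like compound 1 while keeping a single trifluoromethyl group. Because compound 1 gives 1570 nM in this assay, a lower number is expected for compound 3. The expected step is a 2.1-fold lower number from compound 2 to compound 3 (0.32 log units; beyond the scatter). Compound 3 is estimated at 2500 nM, with a range from 1000 nM to 6500 nM.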

Compound 3, concentration for total growth inhibition: 1750 nM
For compound 3 the middle estimate is 1.4-fold (0.15 log units) above the measured one; the measured number falls inside the stated range.
By their numbers in this assay, from the lowest: compounds 1 and 3 (each within the scatter of the next); then compound 2.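

In this assay, (3-(trifluoromethyl)phenyl)amino in place of 3-(trifluoromethyl)phenyl on the carbonyl carbon gives a 3.0-fold lower number from compound 2 to compound 3 (0.47 log units; beyond the scatter), so turning the amide into a urea matters even with a single trifluoromethyl group on each side. Hydrogen in place of the second trifluoromethyl group gives a 1.1-fold higher number from compound 1 to compound 3 (0.05 log units; within the scatter), so that group is not needed to keep this value. Nothing measured here explains these results. The compounds shown leave open whether the urea nitrogen needs its hydrogen, as a methyl group there would test, and whether chlorine or a methoxy group could replace the remaining trifluoromethyl group.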